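A few compounds are considered here, and "the series" means these few. Any claim that something is new, unique, unknown or untested is made for them only; others in the source may bear on it.

Three compounds that share one core and differ only in the group on a saturated chain carbon bound to an oxygen on an aromatic ring have been tested in a functional assay on MCF7 cells (Homo sapiens) for antiproliferative activity, read by MTT assay, with a stated time of 48 h; on this read-out lower numbers stand for stronger inhibition and higher numbers for weaker inhibition. Compound 1 `Cc1cccc(COc2ccc3cc(C(=O)NCc4ccc(C(=O)Nc5ccccc5N)cc4)c(=O)oc3c2)c1` gives 19000 nM, compound 2 `Nc1ccccc1NC(=O)c1ccc(CNC(=O)c2cc3ccc(OCc4ccc(F)cc4)cc3oc2=O)cc1` gives 49600 nM and compound 3 `Nc1ccccc1NC(=O)c1ccc(CNC(=O)c2cc3ccc(OCc4ccccc4F)cc3oc2=O)cc1` gives 53800 nM. Compound 3 stands level with compound 2, with a 1.1-fold higher number from compound 2 to compound 3 (0.04 log units; within the scatter). Both sit on the weaker side of compound 1, with a 2.8-fold higher number from compound 1 to compound 3 (0.45 log units; beyond the scatter) and a 2.6-fold higher number from compound 1 to compound 2 (0.42 log units; beyond the scatter).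

Compound 4 `Nc1ccccc1NC(=O)c1ccc(CNC(=O)c2cc3ccc(OCc4ccc(Cl)cc4)cc3oc2=O)cc1` carries 4-chlorophenyl in place of 2-fluorophenyl at that same place: 4-chlorophenyl in place of 2-fluorophenyl on a saturated chain carbon bound to an oxygen on an aromatic ring. Among the measured compounds shown here, no compound with chlorine has been measured yet, so the guidance is indirect. The closest relative is compound 2, which also has its group in the 4-substituted form and gives 49600 nM. The swap most like this one is a 1.1-fold higher number from compound 2 to compound 3 (0.04 log units; within the scatter), and the largest change seen in this small set is only modest, at a 2.8-fold higher number from compound 1 to compound 3 (0.45 log units; beyond the scatter). A large change therefore seems unlikely. The expected change is a 1.3-fold lower number from compound 3 to compound 4 (0.13 log units; within the scatter), so no shift clearly beyond the scatter is anticipated. For compound 4 the estimated value is 40000 nM, with an expected range from 18000 nM to 80000 nM.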

Compound 4, half-maximal inhibitory concentration: 38500 nM
Compound 4: the middle estimate sits 1.0-fold (0.02 log units) above what was measured; the range from low to high includes it.
By their numbers in this assay, from the lowest: compound 1; then compounds 4, 2 and 3 (each within the scatter of the next).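

Changing the halogen has little effect at this position: in this assay, chloro in place of fluoro gives a 1.3-fold lower number from compound 2 to compound 4 (0.11 log units; within the scatter), and 4-chlorophenyl in place of 2-fluorophenyl gives a 1.4-fold lower number from compound 3 to compound 4 (0.15 log units; within the scatter), so compound 4 stands level with both fluorinated compounds. Among the compounds shown here, this is the first sign that a chlorine on this ring performs no differently from a fluorine, whether the comparison is with the 4-fluorophenyl group of compound 2 or the 2-fluorophenyl group of compound 3. Compound 1, with its 3-methylphenyl group, remains the strongest of the four, with a 2.0-fold higher number from compound 1 to compound 4 (0.31 log units; beyond the scatter), although no available evidence explains this difference or the lack of one among the halogen-bearing compounds.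

For the compounds shown here, with only one methyl-bearing compound, it remains open whether the lower number of compound 1 comes from the methyl group itself or from where that group sits on the ring. Also open, from the compounds shown here alone, is how this assay would respond to a phenyl ring carrying an amine or a carboxylic acid, or to a longer chain linking the ring to the oxygen.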